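Piperazine amide series: fluoro to methoxy on the aryl

A few compounds are considered here, and "the series" means these few. Any claim that something is new, unique, unknown or untested is made for them only; others in the source may bear on it.

Compound 1 `CC(C)(C)OC(=O)N1CCN(C(=O)CCN2C(=O)CSc3ccccc32)CC1` carries a tert-butoxycarbonyl on the amine nitrogen of the ring; in a functional assay (MiaPaCa cells, Homo sapiens) for inhibition, read by sulforhodamine B assay, with a stated time of 48 h (on this read-out lower numbers stand for stronger inhibition of growth and higher numbers for weaker inhibition of growth), compound 1 gives 51500 nM. Compound 2 `O=C(CCN1C(=O)CSc2ccccc21)N1CCN(c2ccccc2F)CC1` has a 2-fluorophenyl in its place. In this assay compound 2 reaches only the limit of the assay, > 100000 nM, so no number is known for it. That limit is all that stands for compound 2 (the limit of > 100000 nM in this assay, at which 1 of the 2 values shown sits). The step of an at least 1.9-fold higher number from compound 1 to compound 2 (0.28 log units; that floor lies within the scatter) therefore has only a floor, and that floor lies within the scatter.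

Compound 3 `COc1ccccc1N1CCN(C(=O)CCN2C(=O)CSc3ccccc32)CC1` differs from compound 2 by methoxy in place of fluoro on an aromatic carbon. Among the compounds with values here, none of the measured steps changes the substituent on this aromatic ring; the one step known, an at least 1.9-fold higher number from compound 1 to compound 2 (0.28 log units; that floor lies within the scatter), swaps the whole group on the amine nitrogen and is of a different kind, so it gives no direction for the present change. The expected step of a number no higher from compound 2 to compound 3 (the limit leaves the size open) is accordingly none beyond the scatter. Compound 3 is estimated at 100000 nM, with a range from 40000 nM to 250000 nM, and a fair chance that this assay again reports only a limit.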

Compound 3, concentration for 50% growth inhibition: 34900 nM
Beside the measured number, compound 3's estimate is 2.9-fold (0.46 log units) above it; the measured number lies below the stated range.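

In this assay, within the data shown here, the substituent on this aromatic carbon, ortho to a large group, now matters: the step of an at least 2.8-fold lower number from compound 2 to compound 3 (0.45 log units; beyond the scatter) is the first to clear the scatter, and it comes from methoxy in place of fluoro alone. For compound 2 the value is a limit and not a number, so the size of this step remains a floor and the true gap may be larger: the limit of > 100000 nM in this assay, at which 1 of the 3 values shown sits. The step of a 1.5-fold lower number from compound 1 to compound 3 (0.17 log units; within the scatter) adds that 2-methoxyphenyl and tert-butoxycarbonyl on the amine nitrogen cannot be told apart on this read-out, so an aryl group on that nitrogen does not in itself rule out a measurable number, with the 2-fluorophenyl of compound 2 as the case against.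

A single pair cannot say whether the difference follows from the methoxy itself or from the absence of fluoro. Also open, on these data alone, is whether a hydroxy, an ethoxy or an amine on the same aromatic carbon would give a lower number than methoxy, or only a limit again.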